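Replacing ethyl with pyridin-2-yl on compound 3

A few compounds are considered here, and "the series" means these few. Any claim that something is new, unique, unknown or untested is made for them only; others in the source may bear on it.

In an ADME assay on microsomes from liver (Homo sapiens) for metabolic stability, read by LC-MS, with a stated time of 10 min (a higher number here means that more of the compound is left, a lower number that less of the compound is left), three compounds sharing one core have been measured. Compound 1 `CC(C)N1CCN(c2cccc3c2C[C@H](CN(C)[C@H]2CCCc4cccnc42)NC3)CC1` gives 56.6%, compound 2 `CN(C[C@H]1Cc2c(cccc2N2CCN(c3ncccn3)CC2)CN1)[C@H]1CCCc2cccnc21` gives 35.5%, and compound 3 `CCN1CCN(c2cccc3c2C[C@H](CN(C)[C@H]2CCCc4cccnc42)NC3)CC1` gives 0%, the lowest of the three. The group on an amine nitrogen in a ring sets them apart, and small changes there have counted: the step of a number 56.6 percentage points lower from compound 1 to compound 3 (beyond the scatter) is large, while the step of a number 21.1 percentage points lower from compound 1 to compound 2 (beyond the scatter) is modest.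

The unmeasured compound 4 `CN(C[C@H]1Cc2c(cccc2N2CCN(c3ccccn3)CC2)CN1)[C@H]1CCCc2cccnc21` differs from compound 3 at that same place: pyridin-2-yl in place of ethyl on an amine nitrogen in a ring. The best guide is the large step with ethyl in place of pyrimidin-2-yl, a number 35.5 percentage points lower from compound 2 to compound 3 (beyond the scatter). The new change runs the other way, with ethyl leaving and an aromatic ring entering, so the number is expected to rise by a large step. That expected step is a number 32 percentage points higher from compound 3 to compound 4 (beyond the scatter). For compound 4 the estimated value is 32%, within an expected range from 12% to 55%.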

Compound 4, percent of the compound remaining: 27.4%
For compound 4 the middle estimate is 4.6 percentage points above the measured one; the range from low to high includes it.
By their numbers in this assay, from the lowest: compound 3; then compounds 4 and 2 (each within the scatter of the next); then compound 1.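

In this assay, pyridin-2-yl on the amine nitrogen in a ring leaves more of the compound than ethyl does (a number 27.4 percentage points higher from compound 3 to compound 4 (beyond the scatter)), so the earlier difference between pyrimidin-2-yl and ethyl is not unique to pyrimidin-2-yl. The two aromatic rings cannot be told apart here (a number 8.1 percentage points lower from compound 2 to compound 4 (within the scatter)), which means that the extra ring nitrogen of pyrimidin-2-yl makes no clear difference in this comparison. Isopropyl goes against any idea that an aromatic ring is the best choice at this position (a number 29.2 percentage points lower from compound 1 to compound 4 (beyond the scatter)), and no measurement available here explains these differences.

It remains open why isopropyl and ethyl, two small chains, lie so far apart. A tert-butyl group or a cyclopropyl ring at this nitrogen could show whether branching of the chain matters more than the presence of a ring.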